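The compounds below may be only part of what the source reports. "The series", "measured", "known", "first", "only" and "open" are said of these compounds alone.

In a functional assay on HCT-116 cells (Homo sapiens) for cytotoxicity, read by MTT assay, with a stated time of 48 h (a higher number here means a weaker inhibitor of growth, a lower number a stronger inhibitor of growth), compound 1 `FC(F)(F)c1nc2cc(Cl)c(Cl)cc2n1CC1CC1` gives 61300 nM. Compound 2 `FC(F)(F)c1nc2cc(Cl)c(Cl)cc2n1Cc1ccccc1`, with phenyl in place of cyclopropyl on a saturated chain carbon bound to an aromatic nitrogen, gives 8600 nM. That exchange is a 7.1-fold lower number from compound 1 to compound 2 (0.85 log units; beyond the scatter). Compound 3 `O=[N+]([O-])c1ccccc1Cn1c(C(F)(F)F)nc2cc(Cl)c(Cl)cc21`, with nitro in place of hydrogen on an aromatic carbon, gives 5900 nM, and this exchange is a 1.5-fold lower number from compound 2 to compound 3 (0.16 log units; within the scatter). On these numbers, compound 2 cannot be told apart from compound 3, while it stands well clear of compound 1.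

Compound 4 `O=[N+]([O-])c1cccc(Cn2c(C(F)(F)F)nc3cc(Cl)c(Cl)cc32)c1` differs from compound 2 by nitro in place of hydrogen on an aromatic carbon, here meta to a large group. The step to compound 2 from compound 1 concerns a different exchange and offers little guidance. The relevant precedent is compound 3, which has the same exchange at a different place and shows a 1.5-fold lower number from compound 2 to compound 3 (0.16 log units; within the scatter). With this single precedent, no step beyond the scatter is expected in this assay, although a slightly lower number would fit it. The expected step is a 1.3-fold lower number from compound 2 to compound 4 (0.12 log units; within the scatter). Compound 4 is estimated to give 6500 nM, within an expected range of 3000 nM to 14000 nM.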

Compound 4, concentration for 50% growth inhibition: 22800 nM
The estimate for compound 4 lay 3.5-fold (0.55 log units) below the measured number; the measured number lies above the stated range.
By their numbers in this assay, from the lowest: compounds 3 and 2 (each within the scatter of the next); then compound 4; then compound 1.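

In this assay, nitro in place of hydrogen on an aromatic carbon does not give one outcome across the ring. Meta to a large group, the exchange gives a 2.7-fold higher number from compound 2 to compound 4 (0.42 log units; beyond the scatter) and this step lies beyond the scatter, whereas the same exchange at a different place gave a 1.5-fold lower number from compound 2 to compound 3 (0.16 log units; within the scatter) and that step stayed within it. The printed values make the same point directly, with compound 3 at 5900 nM and compound 4 at 22800 nM, so in this pair of compounds the place of the nitro group goes with the number and its mere presence does not settle it; no measurement offered here explains the difference.

The compounds shown leave open whether the higher number belongs to nitro itself or to any substituent at this place, and an amine, a nitrile or a methoxy group meta to a large group would separate those readings. They also leave open how far the result holds on a core carrying other groups, and whether it extends beyond growth inhibition in this one cell line.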